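This account rests on a few compounds, and the source may have more. Where it says the series, first, only, none or still open, it means among the compounds named here.

Compound 1 `O=C(Nc1nc2ccc(Cl)cc2s1)c1cc(-c2ccc(F)cc2)n2nc(-c3ccccc3)cc2n1` gives 9770 nM in a functional assay on HeLa cells (Homo sapiens) for cytotoxicity, read by MTT assay, with a stated time of 48 h; a higher number here means a weaker inhibitor, a lower number a stronger inhibitor. Compound 2 `COc1ccc(-c2cc(C(=O)Nc3nc4ccc(Cl)cc4s3)nc3cc(-c4ccccc4)nn23)cc1` gives 5880 nM in this assay.

The number for compound 2 sits at the low end of the two, but its gap to compound 1 is within the scatter, so the two cannot be told apart. Compound 3 `COc1ccc(-c2cc(C(=O)Nc3nc4ccc(Cl)cc4s3)nc3cc(-c4ccccc4)nn23)cc1OC` carries the change (methoxy in place of hydrogen on an aromatic carbon). Going by the values given here, the one measured step, a 1.7-fold lower number from compound 1 to compound 2 (0.22 log units; within the scatter), also altered the same six-membered aromatic ring of carbon only and stayed within the scatter, so a further methoxy there is expected to shift the number little, if at all. Compound 3 is therefore expected to give 5000 nM, with a range from 2000 nM to 15000 nM. The expected step is a 1.2-fold lower number from compound 2 to compound 3 (0.07 log units; within the scatter), within the scatter.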

Compound 3, half-maximal inhibitory concentration: 9120 nM
Compound 3: middle estimate off by 1.8-fold (0.26 log units), on the low side; measured number inside the range.
By their numbers in this assay, from the lowest: compounds 2, 3 and 1 (each within the scatter of the next).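

In this assay, the step of a 1.6-fold higher number from compound 2 to compound 3 (0.19 log units; within the scatter) shows that a second methoxy on this ring, ortho to a methoxy group, leaves no readable mark on the number. Replacing 4-fluorophenyl with 3,4-dimethoxyphenyl gives a 1.1-fold lower number from compound 1 to compound 3 (0.03 log units; within the scatter) and also stays within the scatter, so these three ring patterns cannot be told apart here. No measured evidence bears on this result.

What the compounds shown leave open is whether any group on this ring can move the number beyond the scatter. An amine or a carboxylic acid at this position would test that.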